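This account rests on a few compounds, and the source may have more. Where it says the series, first, only, none or still open, it means among the compounds named here.

Measured so far:
compound 1 `COc1ccc(OCCCON2C(N)=NC(N)=NC23CCOCC3)cc1`; in an assay on isolated protein for inhibition of Dihydrofolate reductase (Homo sapiens), read by spectrophotometry, using NADPH, with stated times of 5 s and 6 min, tested at 5 uM (on this read-out lower numbers stand for a weaker effect and higher numbers for a stronger effect at the one concentration tested), compound 1 gives > 90%, which is a limit of the assay.
compound 2 `NC1=NC2(CCOCC2)N(OCCCOc2ccc(Cl)cc2)C(N)=N1`; in this assay compound 2 gives > 90%, also a limit of the assay.
compound 3 `NC1=NC2(CCSCC2)N(OCCCOc2ccc(Br)cc2)C(N)=N1`; in this assay compound 3 gives > 90%, again a limit of the assay.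

Compound 1 therefore stands only at a limit in this assay, and its place relative to compound 2 and compound 3 cannot be read, since every value shown is a limit (the limit of > 90% in this assay, at which 3 of the 3 values shown sit). Among the measured compounds shown here, the single step between compounds differing in one place is a step that the two limits leave unreadable from compound 1 to compound 2, whose size stays unreadable because both ends sit at the limit of > 90% in this assay, at which 3 of the 3 values shown sit.

Compound 4 `NC1=NC2(CCOCC2)N(OCCCOc2ccccc2Br)C(N)=N1` differs from compound 1 by 2-bromophenyl in place of 4-methoxyphenyl on an oxygen on a saturated carbon. For the measured compounds named here, no measured step bears directly on this exchange. Compound 2 and compound 3, which carry chloro and bromo groups on the phenyl, sit at the same limit (the limit of > 90% in this assay, at which 3 of the 3 values shown sit), so a step of readable size from compound 1 to compound 4 is not expected, and a step that the limit leaves unreadable from compound 1 to compound 4 is estimated as none beyond the scatter. Compound 4 is expected to give 93%, within 82% to 99%, most probably reported once more only as a limit.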

Compound 4, a percentage reported as inhibition, at one concentration (the size of the read-out at that concentration, not a potency): 83.8%
Compound 4: the middle estimate sits 9.2 percentage points above what was measured; low and high end bracket the measured number.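

Among the compounds shown here, compound 4 gives a number where the earlier compounds gave only limits, so 2-bromophenyl on an oxygen on a saturated carbon is the first exchange at this position with a readable bound in this assay. The bound is small on both sides: the record shows (a number at least 6.2 percentage points lower from compound 1 to compound 4 (that floor lies within the scatter)) and (a number at least 6.2 percentage points lower from compound 2 to compound 4 (that floor lies within the scatter)) , so neither step by itself establishes a loss of effect. The true size of both steps stays unreadable because compound 1 and compound 2 are held at a limit: the limit of > 90% in this assay, at which 3 of the 4 values shown sit.

The compounds shown leave open whether any drop belongs to the bromo group or to its place on the ring, since 2-chlorophenyl and 4-bromophenyl do not appear on the core of compound 4. Going by these compounds, how an amine or a carboxylic acid on the phenyl, or a longer chain at this oxygen, would read also remains open.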